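The source may hold more compounds than are shown below. What is called first, only, known or untested is meant among the compounds shown, and "the series" means these compounds.

Compound 1 `O=C(Nc1cccc(-n2cc(-c3ccncc3)c(-c3ccc(Cl)c(O)c3)n2)c1)Nc1ccc(Cl)c(Cl)c1` gives in a functional assay on HT-29 cells (Homo sapiens) for inhibition, read by sulforhodamine B assay, with a stated time of 48 h (a lower number here means that less compound is tolerated, a higher number that more compound is tolerated), only a limit, > 32500 nM. Compound 2 `COc1cc(-c2nn(-c3cccc(NC(=O)c4ccc(Cl)c(C(F)(F)F)c4)c3)cc2-c2ccncc2)ccc1Cl` likewise gives only a limit in this assay, namely > 32500 nM. Among the compounds with values here, compound 3 `O=C(Nc1cccc(-n2cc(-c3ccncc3)c(-c3ccc(Cl)c(O)c3)n2)c1)Nc1cc(C(F)(F)F)cc(C(F)(F)F)c1` is the one compound here with a measured number, 4670 nM in this assay, while the limit of > 32500 nM in this assay, at which 2 of the 3 values shown sit, marks where the other two stop. Compound 4 `COc1cc(-c2nn(-c3cccc(NC(=O)Nc4cc(C(F)(F)F)cc(C(F)(F)F)c4)c3)cc2-c2ccncc2)ccc1Cl` has not yet been measured. Compound 4 differs from compound 3 by methyl in place of hydrogen on an oxygen on an aromatic ring. Within the data shown here, no step between two measured compounds tests this change, so the expectation rests on compound 3 alone. The expected step is a 1.7-fold higher number from compound 3 to compound 4 (0.23 log units; within the scatter), small and towards more compound being tolerated. Compound 4 is estimated at 8000 nM, within a range from 3000 nM to 32500 nM.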

Compound 4, concentration lethal to 50% of the cells: 3710 nM
The estimate for compound 4 lay 2.2-fold (0.33 log units) above the measured number, and the stated range covers the measured number.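

Within the data shown here, this pair is the first direct test of the change on the 4-chloro-3-hydroxyphenyl group. In this assay it gives a 1.3-fold lower number from compound 3 to compound 4 (0.10 log units; within the scatter), so hydroxy and methoxy at this position cannot be told apart here, and capping the oxygen with methyl leaves the reading unresolved from that of the free hydroxy compound. Compound 1 and compound 2 stop at a limit, so they add no number to this comparison: the limit of > 32500 nM in this assay, at which 2 of the 4 values shown sit.

The compounds shown leave open whether a longer chain on this oxygen, such as ethoxy, would read the same. They also leave open whether an amine in place of the hydroxy would do so.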